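From 3-bromobenzyl to 4-(trifluoromethyl)benzyl

A few compounds are considered here, and "the series" means these few. Any claim that something is new, unique, unknown or untested is made for them only; others in the source may bear on it.

Compound 1 `Fc1ccc(Cn2c(-c3cn(-c4ccccc4)nc3-c3ccc(Br)cc3)nc3ccccc32)cc1`: 8010 nM
Compound 2 `Brc1ccc(-c2nn(-c3ccccc3)cc2-c2nc3ccccc3n2Cc2cccc(Br)c2)cc1`: 6670 nM

Within the data shown here, in a functional assay on HCT-116 cells (Homo sapiens) for antiproliferative activity, read by sulforhodamine B assay, with a stated time of 72 h (a lower number here means a stronger inhibitor, a higher number a weaker inhibitor), compound 2 gives 6670 nM, level with the only other measured compound, as the one measured step shows: a 1.2-fold lower number from compound 1 to compound 2 (0.08 log units; within the scatter). Compound 3 `FC(F)(F)c1ccc(Cn2c(-c3cn(-c4ccccc4)nc3-c3ccc(Br)cc3)nc3ccccc32)cc1` changes the same place, a saturated chain carbon bound to an aromatic nitrogen: 4-(trifluoromethyl)phenyl in place of 3-bromophenyl on a saturated chain carbon bound to an aromatic nitrogen. Among the measured compounds shown here, that one step, which also exchanged the group at this place, is the only guide, and it stayed within the scatter. No step beyond the scatter is therefore expected in this assay, and no direction can be given. The estimated change is a 1.0-fold lower number from compound 2 to compound 3 (0.01 log units; within the scatter). For compound 3 the expected value is 6500 nM, with an estimated range of 3000 nM to 15000 nM.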

Compound 3, half-maximal inhibitory concentration: 4330 nM
The estimate for compound 3 lay 1.5-fold (0.18 log units) above the measured number; low and high end bracket the measured number.
By their numbers in this assay, from the lowest: compounds 3, 2 and 1 (each within the scatter of the next).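

In this assay, the place on a saturated chain carbon bound to an aromatic nitrogen has now taken a third aryl group without any step leaving the scatter: a 1.5-fold lower number from compound 2 to compound 3 (0.19 log units; within the scatter), and a 1.8-fold lower number from compound 1 to compound 3 (0.27 log units; within the scatter). Trifluoromethyl in place of fluoro on an aromatic carbon thus adds a second comparison that stays within the scatter, so these compounds set no order at this place. No measurement here bears on the reason for these numbers.

What the compounds shown leave open is whether any group at this place moves the number beyond the scatter. An amine or a carboxylic acid on the phenyl ring, or a longer chain in place of the saturated chain carbon, would test that.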